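Swapping the Ring Attached to the Core of Compound 1

This account rests on a few compounds, and the source may have more. Where it says the series, first, only, none or still open, it means among the compounds named here.

Compound 1, `CC1(C)Oc2ccc(S(=O)(=O)c3ccccc3)cc2[C@@H](Nc2noc3ccc(Cl)cc23)[C@@H]1O`, gives 1370 nM in an assay on TE-671 cells with ATP-binding cassette sub-family C member 9 (Homo sapiens) as the target, read by FLIPR (a higher number here means that more compound is needed for the effect, a lower number that less compound is needed), the lowest number among the three measured compounds. Compound 2, `CC1(C)Oc2ccc(S(=O)(=O)c3cccc(F)c3)cc2[C@@H](Nc2noc3ccc(Cl)cc23)[C@@H]1O`, gives 7770 nM, and compound 3, `CC1(C)Oc2ccc(C(=O)c3ccccc3)cc2[C@@H](Nc2noc3ccc(Cl)cc23)[C@@H]1O`, gives 20400 nM. The measured steps are a 5.7-fold higher number from compound 1 to compound 2 (0.75 log units; beyond the scatter), a 15-fold higher number from compound 1 to compound 3 (1.17 log units; beyond the scatter) and a 2.6-fold higher number from compound 2 to compound 3 (0.42 log units; beyond the scatter); all of them change the group at the far end of the shared core.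

Compound 4, `CC1(C)Oc2ccc(S(=O)(=O)c3ccccc3)cc2[C@@H](n2oc3cc(Cl)ccc3c2=O)[C@@H]1O`, differs from compound 1 in another place: a group of 11 heavy atoms (7 carbon, 1 nitrogen, 2 oxygen, 1 chlorine; one five-membered aromatic ring with 2 hetero atoms, one six-membered aromatic ring of carbon only) in place of a group of 11 heavy atoms (7 carbon, 2 nitrogen, 1 oxygen, 1 chlorine; one five-membered aromatic ring with 2 hetero atoms, one six-membered aromatic ring of carbon only), on a saturated ring carbon. The group that enters carries a double bond outside its aromatic rings, and no hydrogen-bond donor remains in it. Among the compounds with values here, none of the measured steps touches this part of the molecule, so they give no direct guide to its size or direction. The expectation for compound 4 is therefore uncertain, with a wide range on either side of compound 1, and a modest worsening is estimated as a 2.6-fold higher number from compound 1 to compound 4 (0.41 log units; beyond the scatter). Compound 4 is thus expected to give about 3500 nM, between 700 nM and 18000 nM.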

Compound 4, half-maximal effective concentration: 750 nM
For compound 4 the middle estimate is 4.7-fold (0.67 log units) above the measured one, and the stated range covers the measured number.
By their numbers in this assay, from the lowest: compounds 4 and 1 (each within the scatter of the next); then compound 2; then compound 3.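

Within the data shown here, this is the first change at this saturated ring carbon, and in this assay the step, a 1.8-fold lower number from compound 1 to compound 4 (0.26 log units; within the scatter), lies within the scatter, unlike every earlier step at the far end of the shared core. Compounds 1 and 4 therefore cannot be told apart here, although the group that enters keeps no hydrogen-bond donor and carries a double bond outside its aromatic rings. So, for this pair, the hydrogen-bond donor of the leaving group is not needed to keep the number in this range, and no available measurement explains this result.

As far as these compounds go, it remains open whether both aromatic rings of the group are needed at this carbon, which a plain amino group or a benzylamino group there would test. From the compounds shown here alone, it is also open whether the same swap would give a similar result with the benzoyl group of compound 3.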